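Dipropylamino in Place of (Methoxycarbonyl)methoxy on Compound 2

The compounds below may be only part of what the source reports. "The series", "measured", "known", "first", "only" and "open" are said of these compounds alone.

Compound 2 `CCNC(=O)c1noc(-c2cc(C(C)C)c(O)cc2O)c1-c1cc(COCC(=O)OC)no1` was tested in a functional assay on HCT-116 cells (Homo sapiens) for inhibition (on this read-out higher numbers stand for weaker inhibition and lower numbers for stronger inhibition), and gave 262 nM. Among the two numbers available this is the highest; its nearest neighbour is compound 1 `CCNC(=O)c1noc(-c2cc(C(C)C)c(O)cc2O)c1-c1cc(CO)no1`, which in this assay gives 13 nM. For the measured compounds named here, the single measured step between them is a 20-fold higher number from compound 1 to compound 2 (1.30 log units; beyond the scatter). For compound 3 `CCNC(=O)c1noc(-c2cc(C(C)C)c(O)cc2O)c1-c1cc(COCC(=O)O)no1` the result in this assay is "not determined" (no result reported), so it adds nothing to the picture.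

The next compound, compound 4 `CCCN(CCC)Cc1cc(-c2c(C(=O)NCC)noc2-c2cc(C(C)C)c(O)cc2O)on1`, differs from compound 2 in one place: dipropylamino in place of (methoxycarbonyl)methoxy on a saturated chain carbon bound to an aromatic carbon. Going by the values given here, only the step of a 20-fold higher number from compound 1 to compound 2 (1.30 log units; beyond the scatter) bears on this change, and it shows that the chain carbon bound to the aromatic carbon tolerates a bare hydroxyl far better than the (methoxycarbonyl)methoxy group. Among the compounds with values here, no measured step covers an amine at this position, so the expectation rests on the removal of the group that compound 2 carries rather than on what enters. The author therefore expects compound 4 to move part of the way back toward the number of compound 1, with a 4.4-fold lower number from compound 2 to compound 4 (0.64 log units; beyond the scatter) expected. In this assay compound 4 is estimated at 60 nM, within a range from 15 nM to 250 nM.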

Compound 4, half-maximal inhibitory concentration: 183 nM
Estimate against measurement, compound 4: 3.1-fold (0.48 log units) below; the range from low to high includes it.
By their numbers in this assay, from the lowest: compound 1; then compounds 4 and 2 (each within the scatter of the next).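

In this assay, dipropylamino in place of (methoxycarbonyl)methoxy on a saturated chain carbon bound to an aromatic carbon gives a 1.4-fold lower number from compound 2 to compound 4 (0.16 log units; within the scatter), so this assay does not separate these two groups, even though one holds carbon and nitrogen only and the other carbon and oxygen only. Set against the hydroxy of compound 1, the same dipropylamino group gives a 14-fold higher number from compound 1 to compound 4 (1.15 log units; beyond the scatter), which means that the large step seen earlier is not confined to (methoxycarbonyl)methoxy: both replacements of hydroxy shown at this place, unlike as they are, stand well apart from compound 1. Nothing in hand accounts for this result or says what the two replacements have in common.

The compounds shown leave open whether the nitrogen or the rest of the group sets the number, and so whether a dimethylamino group, a morpholine ring or a free primary amine on this chain carbon would come closer to compound 1. They also leave open how a simple methoxy group, or a carboxylic acid carried on the chain, would compare with the hydroxy of compound 1.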